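The source may report more compounds than this note shows. Statements on the series, on what has been measured and on what is new or still open speak of the compounds shown alone.

Measured so far in a functional assay on the whole organism for antagonist activity, with Mus musculus as the target; a lower number here means that less compound is needed, a higher number that more compound is needed for the effect:
- compound 1 `CC(=O)N(C)CC#CCN(C)C`: > 10 mg/kg
- compound 2 `COC(=O)N(C)CC#CCN(C)C`: > 30 mg/kg

Both entries are limits and not numbers. Compound 2 stands only at a limit, > 30 mg/kg. Compound 1 is likewise only a limit, > 10 mg/kg.

Compound 3 `COC(=O)N(C)C(C)C#CCN(C)C` differs from compound 2 by one change: methyl in place of hydrogen on a saturated chain carbon bound to an amide-type nitrogen and a triple-bonded carbon.

Among the measured compounds shown here, the only measured step is a step that the two limits leave unreadable from compound 1 to compound 2, methoxy in place of methyl on a carbonyl carbon. Its size cannot be read, and it concerns a different change, so it gives no measure for this one. For the measured compounds named here, no measured compound carries the new methyl. With no size or direction to draw on, no shift beyond the scatter is expected in this assay. The expected step is a number no higher from compound 2 to compound 3 (the limit leaves the size open), and it is read against a limit, so it remains tentative. A report of compound 3 as a limit is also expected to be quite likely. Compound 3 is estimated at 30 mg/kg, with an expected range of 8 mg/kg to 100 mg/kg.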

Compound 3, dose for half-maximal effect: > 100 mg/kg
Compound 3: no number, only a limit; the forecaster's own chance of this, stated with the estimate: 55%; middle value at least 3.3-fold (0.52 log units) away from the limit.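

In this assay compound 3 gives > 100 mg/kg, which is a limit and not a number. Compound 2 gives > 30 mg/kg, also a limit, so no step can be read between compound 2 and compound 3. The compounds shown leave open the size and direction of the effect of methyl in place of hydrogen in this assay.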